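Cytotoxicity notes on amide-linked analogues: step to compound 4

The compounds below may be only part of what the source reports. "The series", "measured", "known", "first", "only" and "open" are said of these compounds alone.

Measured so far in a functional assay on MCF7 cells (Homo sapiens) for cytotoxicity, read by MTT assay, with a stated time of 24 h, tested at 0.64 ug/mL; on this read-out higher numbers stand for a stronger effect at the one concentration tested and lower numbers for a weaker effect:
- compound 1, `Cc1ccc2oc(SCC(=O)Nc3ccc(-c4nc(-c5ccccc5)c(-c5ccccc5)n4C)cc3)nc2c1`: 1.1%
- compound 2, `Cn1ccnc1SCC(=O)Nc1ccc(-c2nc(-c3ccccc3)c(-c3ccccc3)n2C)cc1`: 10.3%
- compound 3, `CCN1CCN(CC(=O)Nc2ccc(-c3nc(-c4ccccc4)c(-c4ccccc4)n3C)cc2)CC1`: 4.7%

Compound 3 is the second highest of the three numbers in this assay, yet its neighbours lie within the scatter on either side: a number 3.6 percentage points higher from compound 1 to compound 3 (within the scatter) and a number 5.6 percentage points lower from compound 2 to compound 3 (within the scatter). For the measured compounds named here, no compound here stands apart from the others beyond the scatter.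

Compound 4, `Cn1c(-c2ccc(NC(=O)CN3CCN(Cc4ccccc4)CC3)cc2)nc(-c2ccccc2)c1-c1ccccc1`, differs from compound 3 in one place: phenyl in place of methyl on a saturated chain carbon bound to an amine nitrogen in a ring. Going by the values given here, none of the measured steps touches this position; the three changes made so far, including a number 9.2 percentage points higher from compound 1 to compound 2 (within the scatter), all sit on the carbon bound to the carbonyl and all stayed within the scatter. Nothing in the series therefore points to a step beyond the scatter in this assay for this change, in either direction, and a number close to that of compound 3 is expected.

Compound 4 is estimated at 6% in this assay, with a range from 0% to 18%. The step this means, a number 1.3 percentage points higher from compound 3 to compound 4 (within the scatter), is expected to lie within the scatter.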

Compound 4, a percentage reported as activity, at one concentration (the size of the read-out at that concentration, not a potency): 7.2%
Estimate against measurement, compound 4: 1.2 percentage points below; measured number inside the range.
By their numbers in this assay, from the lowest: compounds 1, 3, 4 and 2 (each within the scatter of the next).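

In this assay the only step shown at this position, ethyl to benzyl on the ring amine nitrogen, with phenyl in place of methyl on a saturated chain carbon bound to that nitrogen, gives a number 2.5 percentage points higher from compound 3 to compound 4 (within the scatter) and brings in one six-membered aromatic ring of carbon only. Like the changes on the carbon bound to the carbonyl, this one stays within the scatter, so the series now holds steps at two positions and none beyond it. No measurement to hand explains this result or bears on it.

Going by these compounds, whether any group at this position can give a step beyond the scatter stays open, since only ethyl and benzyl stand here; a 4-fluorobenzyl, an acetyl or a free secondary amine would test it. With one concentration and every number within the scatter of the next, the compounds shown also give no ranking.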